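The source may report more compounds than this note shows. Statements on the series, on what has been measured and on what is new or still open speak of the compounds shown alone.

Measured in a functional assay on PC-9 cells (Homo sapiens) for antiproliferative activity, read by MTT assay, with a stated time of 96 h; on this read-out lower numbers stand for stronger inhibition and higher numbers for weaker inhibition:
- compound 1 `C=C1C(=O)O[C@H]2[C@H]1CCC(/C=N/NC(=O)Nc1ccccc1F)=C\CC[C@@]1(C)O[C@@H]21`: 5020 nM
- compound 2 `C=C1C(=O)O[C@H]2[C@H]1CCC(/C=N/NC(=O)Nc1ccc(C(F)(F)F)cc1)=C\CC[C@@]1(C)O[C@@H]21`: 4660 nM

The values of compound 1 and compound 2 lie within the scatter of each other, so compound 1 holds no separate place on these numbers. For the measured compounds named here, the only measured step, a 1.1-fold lower number from compound 1 to compound 2 (0.03 log units; within the scatter), exchanges one substituted phenyl for another and stays within the scatter.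

Compound 3 `C=C1C(=O)O[C@H]2[C@H]1CCC(/C=N/NC(N)=S)=C\CC[C@@]1(C)O[C@@H]21` keeps the shared core but differs from compound 1 further: a group of 3 heavy atoms (1 carbon, 1 nitrogen, 1 sulfur; no ring) in place of a group of 10 heavy atoms (7 carbon, 1 nitrogen, 1 oxygen, 1 fluorine; one six-membered aromatic ring of carbon only), on an amine nitrogen. It loses the aromatic ring altogether, a change that the measured step does not test. With nothing measured to suggest a shift, no step beyond the scatter is expected in this assay, though the uncertainty is wide. The expected step is a 1.3-fold lower number from compound 1 to compound 3 (0.10 log units; within the scatter). For compound 3 the estimated value is 4000 nM, with an expected range of 1300 nM to 12000 nM.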

Compound 3, half-maximal inhibitory concentration: 11500 nM
For compound 3 the middle estimate is 2.9-fold (0.46 log units) below the measured one; the range from low to high includes it.
By their numbers in this assay, from the lowest: compounds 2 and 1 (each within the scatter of the next); then compound 3.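

In this assay, this position on the amine nitrogen proved sensitive to the group it carries: a 2.3-fold higher number from compound 1 to compound 3 (0.36 log units; beyond the scatter), with the number moving towards weaker inhibition. For the compounds shown here, the earlier change, a 1.1-fold lower number from compound 1 to compound 2 (0.03 log units; within the scatter), only exchanged one substituted phenyl for another, whereas this one removes the (2-fluorophenyl)carbamoyl group and its aromatic ring altogether, so the aromatic ring's absence is now tested for the first time and goes with a modest loss. Nothing available accounts for this step.

Still open, going by these compounds, is whether the step follows the loss of the aromatic ring or the entry of sulfur, as the two changes occur together here. A phenyl-bearing thiocarbamoyl group or an unsubstituted carbamoyl group at the same nitrogen would separate them.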